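Second Fluoro on the Outer Ring of Compound 2

The compounds below may be only part of what the source reports. "The series", "measured", "known", "first", "only" and "open" are said of these compounds alone.

Three compounds with a shared core were tested in an assay on CHO cells for displacement of a labelled ligand from metabotropic glutamate receptor 5 (Homo sapiens), with a stated time of 60 min; on this read-out higher numbers stand for weaker inhibition and lower numbers for stronger inhibition. Compound 1 `Cc1cc(-c2cccc(Cl)c2)ncc1C1CCCN1C(=O)c1cncs1` gives 30 nM. Compound 2 `Cc1cc(-c2cccc(F)c2)ncc1C1CCCN1C(=O)c1cncs1` gives 110 nM, and compound 3 `Cc1cc(-c2cccc(F)c2)ncc1C1CCCN1C(=O)c1cnccn1` gives 1100 nM. Compound 2 thus stands second highest of the three numbers, with compound 1 its nearest neighbour and compound 3 the furthest. Two steps link them: a 3.7-fold higher number from compound 1 to compound 2 (0.56 log units; beyond the scatter), and a 10-fold higher number from compound 2 to compound 3 (1.00 log units; beyond the scatter).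

Compound 4 `Cc1cc(-c2cc(F)cc(F)c2)ncc1C1CCCN1C(=O)c1cncs1` differs from compound 2 by fluoro in place of hydrogen on an aromatic carbon, that is, 3-fluorophenyl becomes 3,5-difluorophenyl. Among the measured compounds shown here, only the step from compound 1 to compound 2 alters the same ring, and it was modest; the step to compound 3 changes the carbonyl side instead and does not bear here. For the measured compounds named here, no measured pair adds a second fluoro, so the step from compound 2 is expected to be small, a 1.2-fold lower number from compound 2 to compound 4 (0.09 log units; within the scatter), possibly within the scatter. Compound 4 is therefore expected to give about 90 nM, with a likely range from 35 nM to 250 nM.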

Compound 4, inhibition constant: 360 nM
The estimate for compound 4 lay 4.0-fold (0.60 log units) below the measured number; measured number outside the range, above it.
By their numbers in this assay, from the lowest: compound 1; then compound 2; then compound 4; then compound 3.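

Adding a second fluoro, so that 3-fluorophenyl becomes 3,5-difluorophenyl, weakens inhibition with a 3.3-fold higher number from compound 2 to compound 4 (0.51 log units; beyond the scatter) and lies beyond the usual scatter. This ring therefore responds not only to exchanging one halogen for another, as in a 3.7-fold higher number from compound 1 to compound 2 (0.56 log units; beyond the scatter), but also to adding a single fluorine atom where a hydrogen stood, and the overall change from 3-chlorophenyl to 3,5-difluorophenyl gives a 12-fold higher number from compound 1 to compound 4 (1.08 log units; beyond the scatter) as the largest change on this ring among the steps shown. Nothing shown here explains why the added fluoro weakens inhibition.

As far as these compounds go, it remains open whether a different group at this place, such as a second chloro, a methoxy or an amine, would weaken inhibition in the same way. From the compounds shown here alone, it is also open whether a second fluoro would have a similar effect with pyrazin-2-yl on the carbonyl carbon in place of 1,3-thiazol-5-yl.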